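Removing one ring methyl from compound 3: outlook for compound 4

The compounds below may be only part of what the source reports. "The series", "measured", "known", "first", "only" and "open" are said of these compounds alone.

Measured so far in a functional assay on NUGC-3 cells (Homo sapiens) for antiproliferative activity, read by sulforhodamine B assay; on this read-out lower numbers stand for stronger inhibition of growth and higher numbers for weaker inhibition of growth:
- compound 1 `CC1CC(=O)c2s/c(=N/c3ccccc3)oc2C1`: 1890 nM
- compound 2 `CC1(C)CC(=O)c2s/c(=N/C3CCCCC3)oc2C1`: 11500 nM
- compound 3 `CC1(C)CC(=O)c2s/c(=N/c3ccc(Cl)cc3)oc2C1`: 2940 nM

Among these three, compound 3 stands second highest. Its nearest neighbour on the numbers is compound 1, whose value is within the scatter of that of compound 3; the furthest is compound 2, whose value lies beyond the scatter, higher than that of compound 3. For the measured compounds named here, the three compounds differ from each other in more than one place, so no single step between them is isolated.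

Compound 4 `CC1CC(=O)c2s/c(=N/c3ccc(Cl)cc3)oc2C1` is not yet measured. It differs from compound 3 in one place: hydrogen in place of methyl on a saturated ring carbon. Going by the values given here, no measured pair isolates this change, so the expected size of the step rests on comparison with compound 1, which also carries a single methyl on that carbon and gives 1890 nM in this assay. The change is expected to be small, with no step beyond the scatter, if anything toward a slightly lower number. Compound 4 is therefore expected near 2200 nM, within the range 900 nM to 5500 nM, an estimated step of a 1.3-fold lower number from compound 3 to compound 4 (0.13 log units; within the scatter).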

Compound 4, concentration for 50% growth inhibition: 15900 nM
Estimate against measurement, compound 4: 7.2-fold (0.86 log units) below; the whole stated range lies below it.
By their numbers in this assay, from the lowest: compounds 1 and 3 (each within the scatter of the next); then compounds 2 and 4 (each within the scatter of the next).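

In this assay, hydrogen in place of methyl on a saturated ring carbon gives a 5.4-fold higher number from compound 3 to compound 4 (0.73 log units; beyond the scatter), so this ring carbon is not a silent position when the aromatic ring carries chloro. Chloro in place of hydrogen on an aromatic carbon gives an 8.4-fold higher number from compound 1 to compound 4 (0.92 log units; beyond the scatter), so with a single methyl on the ring carbon, this change goes with weaker inhibition of growth. Nothing available explains either step.

Whether chloro on the aromatic carbon gives a step of similar size or direction when the ring carbon carries two methyls remains open, as the compounds shown hold no pair that isolates that change. Also open, going by these compounds, is how an ethyl on the saturated ring carbon, or a fluoro or methoxy in place of the chloro, would read.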